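Working notes: from compound 1 to compound 3

The source may report more compounds than this note shows. Statements on the series, on what has been measured and on what is new or still open speak of the compounds shown alone.

Of the compounds shown here, two have been measured in a functional assay on DU-145 cells (Homo sapiens) for inhibition, read by MTT assay, with a stated time of 24 h; a lower number here means a stronger inhibitor, a higher number a weaker inhibitor. Compound 1 `CCOC(=O)C1=Cc2ccccc2OC1(OCc1cc(-c2ccc3ccccc3c2)no1)C(F)(F)F` gives 71800 nM, the lowest of the two numbers. Compound 2 `O=C(O)C1=Cc2ccccc2OC1(OCc1cc(-c2ccc3ccccc3c2)no1)C(F)(F)F`, which differs only by hydrogen in place of ethyl on an oxygen next to a carbonyl group, gives 141000 nM; the step of a 2.0-fold higher number from compound 1 to compound 2 (0.29 log units; within the scatter) lies within the scatter, so the two ester and acid forms are not separated by this assay.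

Compound 3 `CCOC(=O)C1=Cc2ccccc2OC1(OCc1cc(-c2ccc(F)cc2)no1)C(F)(F)F` is the next member. It keeps the ethyl ester of compound 1 and changes the group on the five-membered aromatic ring with 1 nitrogen and 1 oxygen: 4-fluorophenyl in place of naphthalen-2-yl on an aromatic carbon. Within the data shown here, no measured step touches that position; the only step recorded concerns the ester end and is itself within the scatter. The expectation for compound 3 therefore rests on compound 1 alone, with no direction beyond the scatter to be claimed. Compound 3 is expected to give 100000 nM, within the range 30000 nM to 400000 nM, which as a step means a 1.4-fold higher number from compound 1 to compound 3 (0.14 log units; within the scatter).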

Compound 3, half-maximal inhibitory concentration: 53500 nM
Compound 3: the middle estimate sits 1.9-fold (0.27 log units) above what was measured, within the range that was stated.
By their numbers in this assay, from the lowest: compounds 3, 1 and 2 (each within the scatter of the next, the first and the last beyond it).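

In this assay, among these compounds, 4-fluorophenyl in place of naphthalen-2-yl on the aromatic carbon of the five-membered aromatic ring with 1 nitrogen and 1 oxygen gives a 1.3-fold lower number from compound 1 to compound 3 (0.13 log units; within the scatter) and so provides the first measured step at this position, one that does not separate the two groups. With the ethyl ester held constant, the group here can go from naphthalen-2-yl, with 2 six-membered aromatic rings of carbon only and 10 heavy atoms, to 4-fluorophenyl, with one such ring and 7 heavy atoms, without a step beyond the scatter. Among the compounds shown here, no supporting measurement bears on why these two groups read alike, and the single step gives no basis for an explanation.

Going by these compounds, it remains open whether a plain phenyl, or a phenyl carrying an amine or a methoxy group in place of the fluorine, would also stay within the scatter of compound 1. On these data alone, it is equally open whether a non-aromatic group at this position, such as cyclohexyl or a longer alkyl chain, would give a step beyond the scatter in either direction.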